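The source may report more compounds than this note shows. Statements on the series, on what has been measured and on what is new or still open speak of the compounds shown alone.

In a functional assay on MOLT-4 cells (Homo sapiens) for inhibition, read by MTT assay, with a stated time of 72 h (a lower number here means a stronger inhibitor, a higher number a weaker inhibitor), two compounds with the same core have been measured so far. Compound 1 `COc1cc(NC(C)CCCNC(=O)NNC(=O)Nc2ccc(Cl)cc2)c2ncccc2c1` gives 186000 nM and compound 2 `COc1cc(NC(C)CCCNC(=O)Nc2ccc(Cl)cc2)c2ncccc2c1` gives 24000 nM, so compound 2 holds the lower number and is the stronger inhibitor of the pair.

The next compound, compound 3 `COc1cc(NC(C)CCCNC(=O)NNC(=O)Nc2cccc(Cl)c2)c2ncccc2c1`, differs from compound 2 by having ((3-chlorophenyl)carbamoyl)amino in place of 4-chlorophenyl on an amide-type nitrogen. This gives compound 3 the longer type of chain found in compound 1, with the chlorine named at position 3 of the phenyl ring rather than position 4.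

For the measured compounds named here, only one measured step bears on this change: a 7.8-fold lower number from compound 1 to compound 2 (0.89 log units; beyond the scatter), a modest step beyond the scatter. The new change largely runs that step in reverse, so a move of similar size towards a higher number, meaning weaker inhibition, seems likely. Going by the values given here, no measured pair shows what moving the chlorine does, which widens the uncertainty.

The expected change is a 6.3-fold higher number from compound 2 to compound 3 (0.80 log units; beyond the scatter). For compound 3 the estimated value is 150000 nM, with an expected range from 50000 nM to 400000 nM.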

Compound 3, half-maximal inhibitory concentration: 93000 nM
Beside the measured number, compound 3's estimate is 1.6-fold (0.21 log units) above it, within the range that was stated.
By their numbers in this assay, from the lowest: compound 2; then compounds 3 and 1 (each within the scatter of the next).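

In this assay, ((3-chlorophenyl)carbamoyl)amino on the amide-type nitrogen again gives a weaker result than 4-chlorophenyl, with a 3.9-fold higher number from compound 2 to compound 3 (0.59 log units; beyond the scatter), so the drop seen with compound 1 also appears with the chlorine named at position 3. The other new comparison, the first to vary the chlorine position, gives a 2.0-fold lower number from compound 1 to compound 3 (0.30 log units; within the scatter), so this assay does not separate compounds 1 and 3, and moving the chlorine has no effect that can be read on this longer group. Nothing available explains why these longer groups give higher numbers than the 4-chlorophenyl of compound 2.

On these data alone, it remains open whether the chlorine position matters when the ring sits directly on the amide-type nitrogen, as in compound 2, since the position has been compared only on the longer group. As far as these compounds go, it is also open what a fluorine, a trifluoromethyl or a bare phenyl ring would give in place of the chlorinated ring.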